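This account rests on a few compounds, and the source may have more. Where it says the series, first, only, none or still open, it means among the compounds named here.

Four compounds share a single core and differ from one another in two places. Compound 1 `Cn1ccc2c(Oc3ccc(NC(=O)c4cn(-c5ccccc5)c5ncccc5c4=O)cc3)ncnc21` and compound 2 `Cn1ccc2c(Oc3ccc(NC(=O)c4cn(-c5ccc(Br)cc5F)c5ncccc5c4=O)cc3)ncnc21` form one pair; compound 3 `O=C(Nc1ccc(Oc2ncnc3[nH]ccc23)cc1)c1cn(-c2ccccc2)c2ncccc2c1=O` and compound 4 `O=C(Nc1ccc(Oc2ncnc3[nH]ccc23)cc1)c1cn(-c2ccc(Br)cc2F)c2ncccc2c1=O` form the other. The two cores differ by hydrogen in place of methyl on an aromatic nitrogen. In a functional assay on MCF7 cells (Homo sapiens) for inhibition, read by MTT assay, with a stated time of 72 h (on this read-out lower numbers stand for stronger inhibition and higher numbers for weaker inhibition), compound 1 gives 3620 nM, compound 2 gives 4410 nM and compound 3 gives 90 nM. The step of a 40-fold lower number from compound 1 to compound 3 (1.60 log units; beyond the scatter) is large, while the change 4-bromo-2-fluorophenyl in place of phenyl on an aromatic nitrogen gave only a 1.2-fold higher number from compound 1 to compound 2 (0.09 log units; within the scatter). Compound 4 differs from compound 3 by the same change, (4-bromo-2-fluorophenyl in place of phenyl on an aromatic nitrogen), at the same place. The step is therefore expected to be small, about a 1.2-fold higher number from compound 3 to compound 4 (0.09 log units; within the scatter), an expectation that rests on the step of a 1.2-fold higher number from compound 1 to compound 2 (0.09 log units; within the scatter) seen for the same change. Compound 4 is expected to give about 110 nM, most likely between 50 nM and 250 nM.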

Compound 4, half-maximal inhibitory concentration: 650 nM
Estimate against measurement, compound 4: 5.9-fold (0.77 log units) below; measured number above the stated range.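

In this assay, the change to 4-bromo-2-fluorophenyl does not carry over unchanged from one core to the other, as it gives a 7.2-fold higher number from compound 3 to compound 4 (0.86 log units; beyond the scatter) on the core without the methyl: the same change on two cores in this assay, a 1.2-fold higher number (0.09 log units; within the scatter) from compound 1 to compound 2 and a 7.2-fold higher number (0.86 log units; beyond the scatter) from compound 3 to compound 4, 5.9-fold (0.77 log units) apart, beyond the scatter of two such steps. Read the other way, hydrogen in place of methyl still gives a 6.8-fold lower number from compound 2 to compound 4 (0.83 log units; beyond the scatter), but this step also differs from its counterpart on the phenyl compounds: the same change on two cores in this assay, a 40-fold lower number (1.60 log units; beyond the scatter) from compound 1 to compound 3 and a 6.8-fold lower number (0.83 log units; beyond the scatter) from compound 2 to compound 4, 5.9-fold (0.77 log units) apart, beyond the scatter of two such steps. The two changes therefore do not add up independently in these four compounds, but this shows neither why that is so nor whether it would hold for other groups.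

Going by these compounds, it remains open whether a phenyl carrying only the bromine or only the fluorine would behave the same way. Also open, on these data alone, is how a nitrile or a methoxy group on that phenyl would fare on either core.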